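A few compounds are considered here, and "the series" means these few. Any claim that something is new, unique, unknown or untested is made for them only; others in the source may bear on it.

Compound 1 `CC(C)(C)CC(=O)Nc1ccc(C(=O)Nc2nccs2)c(Cl)c1` stands lowest of the two numbers at hand in an assay on CHO cells for displacement of a labelled ligand from adenosine receptor A1 (Homo sapiens), read by scintillation counting, with a stated time of 30 min, tested at 10 uM (on this read-out lower numbers stand for less inhibition and higher numbers for more inhibition at the one concentration tested (going by the name of the read-out)), where compound 1 gives 14%. Compound 2 `Cc1ccccc1C(=O)Nc1ccc(C(=O)Nc2nccs2)cc1` gives 47% in this assay, a gap beyond the usual scatter. Compound 3 `Cc1cc(NC(=O)CC(C)(C)C)ccc1C(=O)Nc1nccs1` is not yet measured; it differs from compound 1 by methyl in place of chloro on an aromatic carbon. Going by the values given here, no measured pair shows this change, so no step is known for it, and a step within the scatter is expected in either direction. Compound 3 is expected to give 18%, with a range from 3% to 35%. The expected step of a number 4 percentage points higher from compound 1 to compound 3 (within the scatter) stays within the scatter.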

Compound 3, a percentage reported as inhibition, at one concentration (the size of the read-out at that concentration, not a potency): 36%
Compound 3: the middle estimate sits 18 percentage points below what was measured; the measured number lies above the stated range.
By their numbers in this assay, from the lowest: compound 1; then compound 3; then compound 2.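

Methyl in place of chloro on an aromatic carbon, ortho to a group of 8 heavy atoms and meta to a group of 8 heavy atoms, gives a number 22 percentage points higher from compound 1 to compound 3 (beyond the scatter) in this assay. This first one-place step shows that the read-out responds at this position to an exchange of one heavy atom for another, with the counted donors, acceptors and charge unchanged. Nothing at hand accounts for the size or direction of this step. The compounds shown leave open how an amine, a methoxy group or a longer chain at this aromatic carbon would read in this assay.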